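Chloro to Fluoro Swap Repeated on a Second Core

The source may report more compounds than this note shows. Statements on the series, on what has been measured and on what is new or still open speak of the compounds shown alone.

In a functional assay on the whole organism (strain NMRI) with Mus musculus as the target, with a stated time of 60 min, at a dose of 20 mg/kg by the intraperitoneal route (a higher number here means a stronger effect of the compound at the dose given, a lower number a weaker effect), three compounds have been measured:

compound 1, `Clc1ccc(Cc2nnc(SCc3ccccc3)[nH]2)c(Oc2ccccc2Cl)c1`: 129%
compound 2, `Fc1ccccc1Oc1cc(Cl)ccc1Cc1nnc(SCc2ccccc2)[nH]1`: 179%
compound 3, `Nc1nnc(Cc2ccc(Cl)cc2Oc2ccccc2Cl)o1`: 170%

Compound 1 and compound 2 differ in one place only: fluoro in place of chloro on an aromatic carbon. That single change gave a number 50 percentage points higher from compound 1 to compound 2 (beyond the scatter). Compound 3 carries a different core; the difference between the core of compound 1 and the core of compound 3 is not broken down here. The number for compound 3 is higher than that for compound 1, while compound 3 and compound 2 sit within the usual scatter of each other, so no order between those two can be read.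

Compound 4, `Nc1nnc(Cc2ccc(Cl)cc2Oc2ccccc2F)o1`, has not yet been measured. It differs from compound 3 in one place: fluoro in place of chloro on an aromatic carbon. This is the same change as from compound 1 to compound 2, made on the same kind of place. Going by the values given here, since the one earlier example gave a number 50 percentage points higher from compound 1 to compound 2 (beyond the scatter), an upward step is expected, estimated as a number 30 percentage points higher from compound 3 to compound 4 (beyond the scatter). For compound 4 the expected number is 200%, most likely between 160% and 240%.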

Compound 4, a percentage reported as activity, at one dose (the size of the read-out at that dose, not a potency): 154%
Compound 4: middle estimate off by 46 percentage points, on the high side; measured number below the stated range.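

In this assay, putting fluoro in place of chloro on the core of compound 3 gave a number 16 percentage points lower from compound 3 to compound 4 (beyond the scatter), so the rise seen on the other core did not repeat. Set side by side, the two results clearly differ: the same change on two cores in this assay, a number 50 percentage points higher (beyond the scatter) from compound 1 to compound 2 and a number 16 percentage points lower (beyond the scatter) from compound 3 to compound 4, 66 percentage points apart, beyond the scatter of two such steps. This shows that, in this series, the change from 2-chlorophenyl to 2-fluorophenyl cannot be carried from one core to the other and be trusted to keep its direction, but it does not show why the cores part ways, and with one pair on each core it cannot show which result is more typical.

The compounds shown hold only chloro or fluoro at this place, so it remains open how a methyl group, a methoxy group or a plain hydrogen there would behave on either core. Also open, from the compounds shown here alone, is whether a further pair on each core would follow the same split, since each direction so far rests on a single step.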